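Cyclopropylcarbonyl on the Ring Nitrogen of Compound 1

This account rests on a few compounds, and the source may have more. Where it says the series, first, only, none or still open, it means among the compounds named here.

Compound 1 `Cc1n[nH]c(N)c1-c1ccc(Cl)cc1`: 61100 nM
Compound 2 `CCCC(=O)n1nc(C)c(-c2ccc(Cl)c(Cl)c2)c1N`: > 100000 nM

Among the compounds with values here, in an assay on Sf9 cells for inhibition of mitogen-activated protein kinase kinase kinase 14 (Homo sapiens), read by ADP-Glo, with a stated time of 60 min (a higher number here means a weaker inhibitor, a lower number a stronger inhibitor), compound 1 gives 61100 nM, the only number among the two values shown. For compound 2 the result is the limit of > 100000 nM and not a number. This limit is documented (the limit of > 100000 nM in this assay, at which 1 of the 2 values shown sits). Compound 3 `Cc1nn(C(=O)C2CC2)c(N)c1-c1ccc(Cl)cc1` carries cyclopropylcarbonyl in place of hydrogen on an aromatic nitrogen. Within the data shown here, no measured pair isolates this change, so the step in this assay is estimated rather than derived; the acylated compound 2 reaching the limit points toward a weaker inhibitor. Compound 3 is expected at 150000 nM, within 40000 nM to 600000 nM, an estimated step of a 2.5-fold higher number from compound 1 to compound 3 (0.39 log units; beyond the scatter).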

Compound 3, half-maximal inhibitory concentration: > 100000 nM
Compound 3: only a limit was reported (the forecaster's own chance of this, stated with the estimate: 60%); the middle value does not contradict the limit.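

Cyclopropylcarbonyl in place of hydrogen on an aromatic nitrogen is the first single change at this position that can be read, and in this assay it gives an at least 1.6-fold higher number from compound 1 to compound 3 (0.21 log units; that floor lies within the scatter). That floor does not show a real loss, so the change can only be said not to have produced a measurable number. The result for compound 3 is a limit, and the true size of the step stays unknown: the limit of > 100000 nM in this assay, at which 2 of the 3 values shown sit.

Going by these compounds, whether an acetyl or a plain methyl on this nitrogen would give a number rather than a limit stays open. So does the effect of replacing the amino group of compound 1.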